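A few compounds are considered here, and "the series" means these few. Any claim that something is new, unique, unknown or untested is made for them only; others in the source may bear on it.

The measured compounds:

- compound 1 `Cc1ccccc1-n1nncc1CN1C(=O)C2(C(C#N)=C(N)Oc3c2c2nc4ccccc4nc2c2ccccc32)c2ccccc21`: in a functional assay on HepG2 cells (Homo sapiens) for antiproliferative activity, read by MTT assay, with a stated time of 48 h (on this read-out lower numbers stand for stronger inhibition and higher numbers for weaker inhibition), compound 1 gives > 50000 nM, which is a limit of the assay and not a number.
- compound 2 `N#CC1=C(N)Oc2c(c3nc4ccccc4nc3c3ccccc23)C12C(=O)N(Cc1cnnn1-c1ccc(Br)cc1)c1ccccc12`: in this assay compound 2 gives > 50000 nM, again a limit of the assay.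
- compound 3 `CCc1ccccc1-n1nncc1CN1C(=O)C2(C(C#N)=C(N)Oc3c(N)cc4nc5ccccc5nc4c32)c2ccccc21`: in this assay compound 3 gives 17900 nM.

Going by the values given here, compound 3 therefore stands alone as the only measured number in the set; the other two sit at the limit of > 50000 nM in this assay, at which 2 of the 3 values shown sit, so nothing can be said about how far they lie from compound 3. Among the compounds with values here, the one step between measured compounds is a step that the two limits leave unreadable from compound 1 to compound 2, a change of the group on an aromatic nitrogen from 2-methylphenyl to 4-bromophenyl, and its size is hidden by the two limits.

Compound 4 `N#CC1=C(N)Oc2c(N)cc3nc4ccccc4nc3c2C12C(=O)N(Cc1cnnn1-c1cccc(Br)c1)c1ccccc12` is the next compound to be measured. It differs from compound 3 by 3-bromophenyl in place of 2-ethylphenyl on an aromatic nitrogen. Within the data shown here, this change sits at the same aromatic nitrogen as the step from compound 1 to compound 2, which is the only measured step that bears on it, and that step cannot be read. There is thus no ground to expect a step beyond the scatter in either direction, and the uncertainty is wide. The step from compound 3 to compound 4 is estimated as a 1.1-fold higher number from compound 3 to compound 4 (0.05 log units; within the scatter). Compound 4 is therefore expected to give 20000 nM, with a range from 6000 nM to 60000 nM.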

Compound 4, half-maximal inhibitory concentration: > 50000 nM
Compound 4: no number, only a limit; the forecaster's own chance of this, stated with the estimate: 35%; at least 2.5-fold (0.39 log units) between middle value and limit.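

In this assay, the group on the aromatic nitrogen now shows a readable effect, which the earlier step, hidden by its two limits, could not show: 3-bromophenyl in place of 2-ethylphenyl gives an at least 2.7-fold higher number from compound 3 to compound 4 (0.44 log units; beyond the scatter). Since a higher number stands for weaker inhibition and the rest of the structure stays the same, this position is not a free choice on the core that carries compound 3, and here the change costs activity. The true size of the step remains unknown, as the reading for compound 4 is a limit and not a number, and the set now gathers at that one ceiling: the limit of > 50000 nM in this assay, at which 3 of the 4 values shown sit.

On these data alone, what remains open is which part of the change matters, as the ethyl group leaves, a bromine enters and the substituent's place on the phenyl ring differs, all in a single step. A plain phenyl, or a phenyl carrying an amine or a carboxylic acid, would test whether any group on this ring can bring the number below that of compound 3, which gives 17900 nM.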